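The source may hold more compounds than are shown below. What is called first, only, known or untested is meant among the compounds shown, and "the series" means these compounds.

Measured so far:
- compound 1 `Cc1cc(C)cc(S(=O)(=O)c2cnc3cc(F)ccc3c2N2CCC(C)CC2)c1`, 80% in an assay on isolated protein for displacement of a labelled ligand from metabotropic glutamate receptor 5 (Homo sapiens), with a stated time of 60 min, tested at 1 uM; a higher number here means more inhibition at the concentration tested (going by the name of the read-out), a lower number less inhibition
- compound 2 `CC1CCN(c2c(S(=O)(=O)c3ccc(F)cc3)cnc3cc(F)ccc23)CC1`, 74.5% in this assay

Compound 2 stands beside compound 1 on these two numbers: the step of a number 5.5 percentage points lower from compound 1 to compound 2 (within the scatter) is within the scatter, so the two values cannot be told apart, and neither compound's number can be called the higher one.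

Compound 3 `Cc1ccc(S(=O)(=O)c2cnc3cc(F)ccc3c2N2CCC(C)CC2)cc1F` is the next member. It differs from compound 2 in one place: 3-fluoro-4-methylphenyl in place of 4-fluorophenyl on a sulfonyl sulfur. Among the measured compounds shown here, the only measured step that bears on this change is a number 5.5 percentage points lower from compound 1 to compound 2 (within the scatter), where one aryl group on the sulfonyl sulfur was exchanged for another and the read-out did not move beyond the scatter. A second exchange of the same kind, keeping a fluorine on the ring and adding a methyl, is therefore expected to leave the read-out in the same region; no step beyond the scatter is expected, and the estimated step is a number 2.5 percentage points higher from compound 2 to compound 3 (within the scatter).

Compound 3 is accordingly estimated at 77% in this assay, with a range from 62% to 90%.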

Compound 3, a percentage reported as inhibition, at one concentration (the size of the read-out at that concentration, not a potency): 89%
The estimate for compound 3 lay 12 percentage points below the measured number, within the range that was stated.
By their numbers in this assay, from the lowest: compounds 2, 1 and 3 (each within the scatter of the next, the first and the last beyond it).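

In this assay, among the compounds shown here, the aryl group on the sulfonyl sulfur shows a step beyond the scatter for the first time: 3-fluoro-4-methylphenyl in place of 4-fluorophenyl gives a number 14.5 percentage points higher from compound 2 to compound 3 (beyond the scatter), a modest step. For the compounds shown here, the same group in place of 3,5-dimethylphenyl gives a number 9 percentage points higher from compound 1 to compound 3 (within the scatter), so these two aryl groups cannot be told apart here, and the position separates aryl groups only in the one comparison between 4-fluorophenyl and 3-fluoro-4-methylphenyl, while 3,5-dimethylphenyl stays within the scatter of both. Nothing on hand accounts for the modest step or says what it rests on.

The compounds shown do not separate the two differences within this exchange, the methyl and the place of the fluorine, which 4-methylphenyl and 3-fluorophenyl on the same sulfonyl sulfur would address. They also leave open whether the position accepts anything other than an aryl ring of carbon only carrying fluorine or methyl, such as a pyridyl ring or a ring bearing an amine or a carboxylic acid.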